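The compounds below may be only part of what the source reports. "The series", "measured", "known", "first", "only" and "open" are said of these compounds alone.

In a functional assay on MGC-803 cells (Homo sapiens) for inhibition, read by CCK-8 assay, with a stated time of 48 h (on this read-out lower numbers stand for stronger inhibition and higher numbers for weaker inhibition), three compounds sharing one core have been measured. Compound 1 `COc1cc(N(Cc2ccc(Cl)cc2)C(=O)CSC(=S)N2CCN(C(=O)OC(C)(C)C)CC2)cc(OC)c1OC` gives 12900 nM, compound 2 `COc1ccc(CN(C(=O)CSC(=S)N2CCN(C(=O)OC(C)(C)C)CC2)c2cc(OC)c(OC)c(OC)c2)cc1F` gives 4870 nM, and compound 3 `COc1ccc(CN(C(=O)CSC(=S)N2CCN(C(=O)OC(C)(C)C)CC2)c2cc(OC)c(OC)c(OC)c2)cc1[N+](=O)[O-]` gives 880 nM, the lowest of the three numbers. Compound 4 `COc1ccc(CN(C(=O)CSC(=S)N2CCN(C(=O)OC(C)(C)C)CC2)c2cc(OC)c(OC)c(OC)c2)cc1N=[N+]=[N-]` has not yet been measured. It differs from compound 3 in one group: azido in place of nitro on an aromatic carbon. The azido group of compound 4 sits ortho to a methoxy group. The measured step that bears most directly on this change is a 5.5-fold lower number from compound 2 to compound 3 (0.74 log units; beyond the scatter), where nitro took the place of fluoro. The steps of a 2.6-fold lower number from compound 1 to compound 2 (0.42 log units; beyond the scatter) and a 15-fold lower number from compound 1 to compound 3 (1.17 log units; beyond the scatter) bear on it less directly, as they exchange the whole substituted phenyl group. None of these steps tests azido itself, so the data give only a rough guide. A modest rise in the number is expected, an estimated 2.3-fold higher number from compound 3 to compound 4 (0.36 log units; beyond the scatter). The expected value for compound 4 is 2000 nM, with an estimated range from 600 nM to 6500 nM.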

Compound 4, half-maximal inhibitory concentration: 810 nM
For compound 4 the middle estimate is 2.5-fold (0.39 log units) above the measured one, within the range that was stated.
By their numbers in this assay, from the lowest: compounds 4 and 3 (each within the scatter of the next); then compound 2; then compound 1.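

In this assay the exchange of nitro for azido on this aromatic carbon, ortho to a methoxy group, gives a 1.1-fold lower number from compound 3 to compound 4 (0.04 log units; within the scatter) and so shows that the two groups cannot be told apart at this position. Azido in place of fluoro gives a 6.0-fold lower number from compound 2 to compound 4 (0.78 log units; beyond the scatter) and the whole 3-azido-4-methoxyphenyl group in place of 4-chlorophenyl gives a 16-fold lower number from compound 1 to compound 4 (1.20 log units; beyond the scatter) in the same assay, so the advantage over fluoro and over 4-chlorophenyl is not confined to nitro. No measurement at hand accounts for the close match between azido and nitro.

From the compounds shown here alone, whether an amine, a nitrile or a plain hydrogen at this position would match azido and nitro remains open. Going by these compounds, it is also open whether the two groups would still read alike with a hydroxyl in place of the neighbouring methoxy group.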